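The compounds below may be only part of what the source reports. "The series", "measured", "known", "first", "only" and "open" are said of these compounds alone.

Compound 1 `COc1cccc(-c2nn(-c3ccccc3)cc2-c2ccnc(NCCCNC(=O)c3cccc(C(F)(F)F)c3)c2)c1` was tested in a functional assay on HCT-15 cells (Homo sapiens) for antiproliferative activity (on this read-out higher numbers stand for weaker inhibition of growth and lower numbers for stronger inhibition of growth), and gives 3400 nM. A second compound, compound 2 `COc1cccc(-c2nn(-c3ccccc3)cc2-c2ccnc(NCCNC(=O)Nc3cccc(C(F)(F)F)c3)c2)c1`, gives 1700 nM in this assay. Within the data shown here, these two numbers lie within the usual scatter of each other, so neither compound can be said to inhibit growth more strongly than the other, and no step between them is counted.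

Compound 3 `COc1cccc(-c2nn(-c3ccccc3)cc2-c2ccnc(NCCCNC(=O)Nc3ccc(Cl)c(Cl)c3)c2)c1` has not yet been measured. It differs from compound 1 in one place: (3,4-dichlorophenyl)amino in place of 3-(trifluoromethyl)phenyl on a carbonyl carbon. Among the measured compounds shown here, no measured pair in this set shows what this exchange does on its own. For the measured compounds named here, with only two numbers to lean on, and both of them close together, the step from compound 1 to compound 3 is expected to be small, a 1.5-fold lower number from compound 1 to compound 3 (0.19 log units; within the scatter), with no clear direction beyond the scatter. Compound 3 is therefore estimated at 2200 nM, with a likely range from 700 nM to 7000 nM.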

Compound 3, concentration for 50% growth inhibition: 2400 nM
Compound 3: the middle estimate sits 1.1-fold (0.04 log units) below what was measured; low and high end bracket the measured number.
By their numbers in this assay, from the lowest: compounds 2, 3 and 1 (each within the scatter of the next).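

In this assay, the exchange gives a 1.4-fold lower number from compound 1 to compound 3 (0.15 log units; within the scatter), so the read-out does not separate these two compounds. This shows that the (3,4-dichlorophenyl)carbamoyl group, which carries a hydrogen-bond donor absent from the (3-(trifluoromethyl)phenyl)carbonyl group, can take that group's place without moving growth inhibition beyond the scatter. No measurement here explains why the two groups read alike.

The exchange alters both the substituents on the aromatic ring and the link to the carbonyl carbon, so the compounds shown cannot tell whether either change alone would matter or whether the two offset each other. As far as these compounds go, it also remains open how growth inhibition would respond to a carboxylic acid or a basic amine on the carbonyl carbon, or to a longer chain leading to it.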